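Hydrazone aryl variation on the shared core in HCT-116 cells

The source may hold more compounds than are shown below. What is called first, only, known or untested is meant among the compounds shown, and "the series" means these compounds.

Measured so far:
compound 1 `Cn1c(=O)c(=O)n(C2CCCC2)c2nc(N/N=C/c3ccc(O)c(F)c3)ncc21` gives 59300 nM
compound 2 `COc1ccc(/C=N/Nc2ncc3c(n2)n(C2CCCC2)c(=O)c(=O)n3C)cc1` gives 36100 nM

In a functional assay on HCT-116 cells (Homo sapiens) for antiproliferative activity, read by MTT assay (a higher number here means a weaker inhibitor, a lower number a stronger inhibitor), compound 1 gives the highest of the two numbers; its nearest neighbour is compound 2, and the step of a 1.6-fold lower number from compound 1 to compound 2 (0.22 log units; within the scatter) replaces 3-fluoro-4-hydroxyphenyl by 4-methoxyphenyl on a carbon with a double bond to nitrogen without leaving the scatter.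

Compound 3 `Cn1c(=O)c(=O)n(C2CCCC2)c2nc(N/N=C/c3ccc(F)cc3F)ncc21` is not yet measured. It differs from compound 1 by 2,4-difluorophenyl in place of 3-fluoro-4-hydroxyphenyl on a carbon with a double bond to nitrogen.

Going by the values given here, the only step that bears on this change is the one from compound 1 to compound 2, in which another aryl swap at the same carbon gave a 1.6-fold lower number from compound 1 to compound 2 (0.22 log units; within the scatter). On that basis the swap to 2,4-difluorophenyl is expected to give no step beyond the scatter in this assay, and the expected step is a 1.2-fold lower number from compound 1 to compound 3 (0.07 log units; within the scatter).

Compound 3 is therefore estimated at 50000 nM, in the range 20000 nM to 130000 nM.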

Compound 3, half-maximal inhibitory concentration: 19800 nM
Beside the measured number, compound 3's estimate is 2.5-fold (0.40 log units) above it; the whole stated range lies above it.
By their numbers in this assay, from the lowest: compounds 3, 2 and 1 (each within the scatter of the next, the first and the last beyond it).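

In this assay, the aryl group on the carbon with a double bond to nitrogen can produce a step beyond the scatter: 2,4-difluorophenyl in place of 3-fluoro-4-hydroxyphenyl gives (a 3.0-fold lower number from compound 1 to compound 3 (0.48 log units; beyond the scatter)), which the earlier pair did not show. The same group in place of 4-methoxyphenyl stays within the scatter (a 1.8-fold lower number from compound 2 to compound 3 (0.26 log units; within the scatter)), so of the three compounds only compound 1 and compound 3 stand apart, and compound 2 separates from neither. No measurement at hand accounts for the step between compound 1 and compound 3.

On these data alone, whether that step goes with the loss of the hydroxyl or with the gain of a second fluorine stays open, as both come together in this change. As far as these compounds go, how the position responds to a phenyl group carrying an amine or a carboxylic acid also remains open.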